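The source may report more compounds than this note shows. Statements on the series, on what has been measured and on what is new or still open speak of the compounds shown alone.

Working notes on the series. Of the compounds shown here, three sharing one core have been measured in an ADME assay on L02 cells (Homo sapiens) for cytotoxicity, read by MTT assay, with a stated time of 72 h; a higher number here means a weaker inhibitor, a lower number a stronger inhibitor: compound 1 `Cc1ccccc1NC(=O)CCC(=O)OCCCCCCSc1ccc([N+](=O)[O-])c2nonc12` gives 9490 nM, compound 2 `O=C(CCC(=O)OCCCCCCSc1ccc([N+](=O)[O-])c2nonc12)Nc1ccc(F)cc1` gives 6460 nM, and compound 3 `O=C(CCC(=O)OCCCCCCSc1ccc([N+](=O)[O-])c2nonc12)Nc1ccc(Br)cc1` gives 4330 nM. Compound 2 stands second highest of the three, and its steps to both neighbours are within the scatter: a 1.5-fold lower number from compound 1 to compound 2 (0.17 log units; within the scatter), and a 1.5-fold lower number from compound 2 to compound 3 (0.17 log units; within the scatter). Going by the values given here, the only step read as beyond the scatter is a 2.2-fold lower number from compound 1 to compound 3 (0.34 log units; beyond the scatter), a modest one.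

Compound 4 `O=C(CCC(=O)N1CCOCC1)OCCCCCCSc1ccc([N+](=O)[O-])c2nonc12` is not yet measured. It differs from compound 2 in one place: morpholin-4-yl in place of (4-fluorophenyl)amino on a carbonyl carbon. Among the compounds with values here, none of the measured steps makes this change; all three vary the aryl group on the amide-type nitrogen, and together they span a narrow range. No information bears directly on exchanging (4-fluorophenyl)amino for morpholin-4-yl, so the expectation rests only on the narrow spread seen so far. For compound 4 the expected step is a 1.2-fold higher number from compound 2 to compound 4 (0.06 log units; within the scatter), not beyond the scatter in either direction. The estimate for compound 4 in this assay is therefore 7500 nM, with a range of 3000 nM to 19000 nM.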

Compound 4, half-maximal inhibitory concentration: 3240 nM
Compound 4: the middle estimate sits 2.3-fold (0.36 log units) above what was measured, and the stated range covers the measured number.
By their numbers in this assay, from the lowest: compounds 4, 3, 2 and 1 (each within the scatter of the next, the first and the last beyond it).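

Exchanging the aryl amino group for morpholin-4-yl on this carbonyl carbon takes out the aromatic ring and the amide hydrogen, and in this assay this change gives a 2.0-fold lower number from compound 2 to compound 4 (0.30 log units; within the scatter) and a 1.3-fold lower number from compound 3 to compound 4 (0.13 log units; within the scatter) while the comparison with the third aryl compound gives a 2.9-fold lower number from compound 1 to compound 4 (0.47 log units; beyond the scatter) as a modest step. Among these four compounds, then, neither an aromatic ring nor the amide hydrogen at this place is needed for a number in this range, and compound 4 is separated beyond the scatter only from compound 1. The data shown offer no measurement that accounts for this result.

Going by these compounds, it remains open how a piperidin-1-yl group or a free carboxylic acid at this carbonyl carbon would read in this assay. A longer chain in the shared core is equally untested in the compounds shown here.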